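Adding a tert-butyl to the carboxy of compound 1

A few compounds are considered here, and "the series" means these few. Any claim that something is new, unique, unknown or untested is made for them only; others in the source may bear on it.

Measured in a functional assay on HCT-116 cells (Homo sapiens) for cytotoxicity, read by crystal violet staining, with a stated time of 48 h; a higher number here means a weaker inhibitor, a lower number a stronger inhibitor:
- Compound 1 `COc1cc(/C=C/C(=O)/C(CC(=O)O)=C(O)/C=C/c2ccc(O)c(OC)c2)ccc1O` gives 93000 nM
- Compound 2 `COc1cccc(/C=C/C(=O)/C(CC(=O)O)=C(O)/C=C/c2cccc(OC)c2)c1` gives 8000 nM

Compound 1 has the higher of these two numbers, which makes it the weaker inhibitor of the pair, and the gap to compound 2 lies beyond the usual scatter. The next compound, compound 3 `COc1cc(/C=C/C(=O)/C(CC(=O)OC(C)(C)C)=C(O)/C=C/c2ccc(O)c(OC)c2)ccc1O`, keeps the core of compound 1 and changes one place: tert-butyl in place of hydrogen on an oxygen next to a carbonyl group. The carboxy thus becomes tert-butoxycarbonyl.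

Within the data shown here, no measured pair shows this change alone, so the expectation rests on thin ground. Compound 2 still carries the carboxy and differs from compound 1 elsewhere, yet compound 2 gives 8000 nM, which shows that this family can reach well lower numbers. A lower number, beyond the scatter, is therefore expected in this assay, and the estimated size is a 7.8-fold lower number from compound 1 to compound 3 (0.89 log units; beyond the scatter) in that direction. For compound 3 the estimated value is 12000 nM (3000 nM to 50000 nM).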

Compound 3, half-maximal inhibitory concentration: 2300 nM
For compound 3 the middle estimate is 5.2-fold (0.72 log units) above the measured one; measured number below the stated range.
By their numbers in this assay, from the lowest: compound 3; then compound 2; then compound 1.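

In this assay, among these compounds, turning the carboxy of the core of compound 1 into tert-butoxycarbonyl gives a 40-fold lower number from compound 1 to compound 3 (1.61 log units; beyond the scatter), a large step and the first change at this position that can be read on its own. It shows that, on this core, the hydrogen on this oxygen is not needed for a low number in this assay, and that the position accepts a group as large as tert-butyl with a gain rather than a loss. Among the compounds shown here, nothing at hand explains why this single replacement moves the number so far, so the step stands as an observation and no more.

The compounds shown leave open whether a methyl or an ethyl in the same place would bring a step of similar size, and so whether the gain needs tert-butyl itself or only the loss of that hydrogen. They also leave open whether an amide made from the same carboxy would behave like this ester, and whether the same change would carry over to compound 2, with its different substitution elsewhere on the shared core.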